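Removing the bromine from a five-membered lactone core

This account rests on a few compounds, and the source may have more. Where it says the series, first, only, none or still open, it means among the compounds named here.

The compounds measured so far, with their values in a functional assay on B16 cells (Mus musculus) for cytotoxicity, read by MTT assay; a higher number here means a weaker inhibitor, a lower number a stronger inhibitor:

compound 1, `CC(=O)O[C@@H]1OC(=O)[C@](Cc2ccccc2)(C(C)=O)[C@@H]1C` — compound 1 gives 41000 nM.
compound 2, `CC(=O)O[C@@H]1OC(=O)[C@](O)(C(C)=O)[C@@H]1C` — compound 2 gives > 50000 nM.
compound 3, `CC(=O)O[C@@H]1OC(=O)[C@](Br)(C(C)=O)[C@@H]1C` — compound 3 gives 9000 nM.

The reading of compound 2 is a limit of the assay and not a number; it is the limit of > 50000 nM in this assay, at which 1 of the 3 values shown sits. Among the two real numbers compound 3 holds the lower one, and its nearest neighbour is compound 1, the change being a 4.6-fold lower number from compound 1 to compound 3 (0.66 log units; beyond the scatter). The step from the hydroxy compound is an at least 5.5-fold lower number from compound 2 to compound 3 (0.74 log units; beyond the scatter), and that between the benzyl and hydroxy compounds is an at least 1.2-fold higher number from compound 1 to compound 2 (0.08 log units; that floor lies within the scatter).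

Compound 4, `CC(=O)O[C@@H]1OC(=O)[C@@H](C(C)=O)[C@@H]1C`, has not been measured. It differs from compound 3 by hydrogen in place of bromo on a saturated ring carbon. The measured steps all concern what replaces the benzyl, the hydroxy or the bromo group on that saturated ring carbon; none of them places a hydrogen there. What they show is that the bromo compound stands apart from the other two, which sit close together or at the limit. On that basis compound 4 is expected to fall back toward the weaker compounds, a change of a 3.3-fold higher number from compound 3 to compound 4 (0.52 log units; beyond the scatter) in this assay. The estimate for compound 4 is 30000 nM, within 10000 nM to 90000 nM.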

Compound 4, half-maximal inhibitory concentration: > 50000 nM
Compound 4: no number, only a limit (the forecaster's own chance of this, stated with the estimate: 30%); at least 1.6-fold (0.22 log units) between middle value and limit.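

Compound 4 gives only a limit of the assay in this assay, not a number: the limit of > 50000 nM in this assay, at which 2 of the 4 values shown sit.

Hydrogen on this saturated ring carbon provides the comparison that the earlier compounds lacked, and the change is an at least 5.5-fold higher number from compound 3 to compound 4 (0.74 log units; beyond the scatter), so among these compounds the lower number goes with bromo and does not appear with hydrogen, hydroxy or benzyl at this place. The change on the benzyl side is an at least 1.2-fold higher number from compound 1 to compound 4 (0.08 log units; that floor lies within the scatter), which leaves hydrogen and benzyl not separated in this assay, while the step between the hydroxy and hydrogen compounds cannot be read, as both readings are limits.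

The compounds shown leave open whether another halogen such as chlorine or iodine, or an amine, on this saturated ring carbon would keep the lower number seen with bromo. They also leave open whether the effect of bromo holds when a longer ester chain replaces the acetoxy group on the ring atom that bears it.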